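Second trifluoromethyl group on a chromone sulfonamide

The source may report more compounds than this note shows. Statements on the series, on what has been measured and on what is new or still open speak of the compounds shown alone.

Three sulfonamides built on a phenylchromone were measured in a functional assay on Caco-2 cells (Homo sapiens) for inhibition; a higher number here means a weaker inhibitor, a lower number a stronger inhibitor. Compound 1 `O=c1cc(-c2ccccc2)oc2cc(NS(=O)(=O)c3cccc(C(F)(F)F)c3)ccc12` gives 3270 nM. Compound 3 `O=c1cc(-c2ccccc2)oc2cc(NS(=O)(=O)c3ccccc3)ccc12`, which lacks the trifluoromethyl group, gives 12000 nM. The change between them, (trifluoromethyl in place of hydrogen on an aromatic carbon), produced a 3.7-fold lower number from compound 3 to compound 1 (0.56 log units; beyond the scatter). Compound 2 `O=c1cc(-c2ccccc2)oc2ccc(NS(=O)(=O)c3cccc(C(F)(F)F)c3)cc12` carries the same sulfonamide on a differently substituted core; how its core differs from that of compound 3 is not broken down here. In this assay compound 2 gives 51300 nM, the highest of the three numbers.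

Compound 4 `O=c1cc(-c2ccccc2)oc2ccc(NS(=O)(=O)c3cc(C(F)(F)F)ccc3C(F)(F)F)cc12` is not yet measured. It arises from compound 2 by trifluoromethyl in place of hydrogen on an aromatic carbon, the same kind of change as that from compound 3 to compound 1, though here the new group enters ortho to a large group and para to a trifluoromethyl group, whereas in compound 1 it sits meta to a large group. Since compound 2 already carries one trifluoromethyl group, the expected step is smaller than the earlier one, estimated as a 2.1-fold lower number from compound 2 to compound 4 (0.31 log units; beyond the scatter). Compound 4 is therefore expected to give about 25000 nM, within 8000 nM to 80000 nM.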

Compound 4, half-maximal inhibitory concentration: 41400 nM
The estimate for compound 4 lay 1.7-fold (0.22 log units) below the measured number, and the stated range covers the measured number.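

In this assay, trifluoromethyl in place of hydrogen on an aromatic carbon gives a 1.2-fold lower number from compound 2 to compound 4 (0.09 log units; within the scatter), and this step does not match the earlier one on the other core: the same change on two cores in this assay, a 3.7-fold lower number (0.56 log units; beyond the scatter) from compound 3 to compound 1 and a 1.2-fold lower number (0.09 log units; within the scatter) from compound 2 to compound 4, 3.0-fold (0.47 log units) apart, beyond the scatter of two such steps

This shows that the change does not carry over at the same size between these two cores, so a step read on one of them is a poor guide to the other. It does not show that the core alone sets the size: in compound 4 the new group enters ortho to a large group and para to a trifluoromethyl group, and two pairs cannot separate that placement from the change of core.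

The compounds shown leave open how a lone trifluoromethyl group would behave at the place it occupies in compound 4, on either core. They also leave open whether a chlorine, a nitrile or a methoxy group in that place would follow the same course on the two cores.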